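The source may report more compounds than this note shows. Statements on the series, on what has been measured and on what is new or still open speak of the compounds shown alone.

In a functional assay on CaEs17 cells (Homo sapiens) for cytotoxicity, read by MTT assay, with a stated time of 72 h (a higher number here means a weaker inhibitor, a lower number a stronger inhibitor), three compounds that share one core and differ only in the group on an ester carbonyl carbon have been measured. Compound 1 `C=C1C(=O)[C@@]23C(=O)OC[C@]4(C(=O)CCC(C)(C)[C@H]4C=O)[C@@H]2CC[C@@H]1[C@H]3OC(C)=O` gives 1350 nM, compound 2 `C=C1C(=O)[C@@]23C(=O)OC[C@]4(C(=O)CCC(C)(C)[C@H]4C=O)[C@@H]2CC[C@@H]1[C@H]3OC(=O)CC` gives 1400 nM, and compound 3 `C=C1C(=O)[C@@]23C(=O)OC[C@]4(C(=O)CCC(C)(C)[C@H]4C=O)[C@@H]2CC[C@@H]1[C@H]3OC(=O)c1ccccc1` gives 1710 nM. Compound 3 therefore stands level with the other two, as all three numbers lie within the scatter of one another.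

Compound 4 `C=C1C(=O)[C@@]23C(=O)OC[C@]4(C(=O)CCC(C)(C)[C@H]4C=O)[C@@H]2CC[C@@H]1[C@H]3OC(=O)c1ccc(C(F)(F)F)cc1` keeps all of compound 3 except for one change: trifluoromethyl in place of hydrogen on an aromatic carbon. This puts trifluoromethyl in place of hydrogen on an aromatic carbon, para to a large group.

For the measured compounds named here, the steps that bear on this change are those made in the same part of the molecule: a 1.0-fold higher number from compound 1 to compound 2 (0.02 log units; within the scatter), a 1.3-fold higher number from compound 1 to compound 3 (0.10 log units; within the scatter) and a 1.2-fold higher number from compound 2 to compound 3 (0.09 log units; within the scatter). All three stay within the scatter, but none adds anything to the aromatic ring, so the data offer only indirect guidance. No step beyond the scatter is expected in this assay, and the expected step is a 1.1-fold higher number from compound 3 to compound 4 (0.02 log units; within the scatter). Compound 4 is estimated at about 1800 nM, with an expected range from 900 nM to 3500 nM.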

Compound 4, half-maximal inhibitory concentration: 8960 nM
Compound 4: middle estimate off by 5.0-fold (0.70 log units), on the low side, and the stated range ends below it.
By their numbers in this assay, from the lowest: compounds 1, 2 and 3 (each within the scatter of the next); then compound 4.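

In this assay the aromatic ring of the benzoyl ester proves sensitive to change: adding trifluoromethyl on an aromatic carbon, para to a large group, gives a 5.2-fold higher number from compound 3 to compound 4 (0.72 log units; beyond the scatter) and so moves the compound toward weaker inhibition, whereas swapping among the three unsubstituted esters had moved nothing beyond the scatter. The smaller esters point the same way, with a 6.4-fold higher number from compound 2 to compound 4 (0.81 log units; beyond the scatter) and a 6.6-fold higher number from compound 1 to compound 4 (0.82 log units; beyond the scatter) as the printed steps, so compound 4 alone stands apart from the group. Nothing available here explains this shift.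

Still open, as far as these compounds go, is whether the step belongs to trifluoromethyl itself or would follow any group on that carbon, such as a methyl, a chlorine or a methoxy group. An amine or a carboxylic acid there could show whether the ring tolerates any substituent at all.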